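The compounds below may be only part of what the source reports. "The series", "measured", "known", "first", "only" and "open" are said of these compounds alone.

Measured compounds in this series:
compound 1, `CCCCNC(=O)OC/C=C(\C)C1=CC(=O)C(C)(C)O1`, 1.2 ug/mL
compound 2, `C=CCNC(=O)OC/C=C(\C)C1=CC(=O)C(C)(C)O1`, 2.8 ug/mL

In a functional assay on MT4 cells (Homo sapiens) for inhibition (on this read-out higher numbers stand for weaker inhibition and lower numbers for stronger inhibition), compound 1 gives 1.2 ug/mL, and in the same read-out compound 2 gives 2.8 ug/mL. Among the measured compounds shown here, compound 2 thus stands with the higher of the two numbers, its nearest neighbour being compound 1; the one measured step between them is a 2.3-fold higher number from compound 1 to compound 2 (0.37 log units; beyond the scatter), a modest weakening on exchanging the saturated chain for the one carrying a double bond.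

Compound 3, `C/C(=C\COC(=O)NC1CCCCC1)C1=CC(=O)C(C)(C)O1`, is not yet measured. Relative to compound 2 the change is cyclohexyl in place of allyl on an amide-type nitrogen. For the measured compounds named here, the single step that bears on this is a 2.3-fold higher number from compound 1 to compound 2 (0.37 log units; beyond the scatter): it shows that removing the double bond from the chain on the amide-type nitrogen, as in compound 1, went with a lower number. Compound 3 likewise carries a saturated group in that place, though now a ring rather than a chain, so the expectation is a modest step back down, roughly reversing the measured one, that is a 2.3-fold lower number from compound 2 to compound 3 (0.37 log units; beyond the scatter). Going by these compounds, the estimate for compound 3 is 1.2 ug/mL, with a range of 0.4 ug/mL to 3.5 ug/mL; the ring is untested here, so the range is kept wide.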

Compound 3, half-maximal inhibitory concentration: 2.4 ug/mL
The estimate for compound 3 lay 2.0-fold (0.30 log units) below the measured number; the measured number falls inside the stated range.
By their numbers in this assay, from the lowest: compounds 1, 3 and 2 (each within the scatter of the next, the first and the last beyond it).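

In this assay, cyclohexyl in place of allyl on the amide-type nitrogen gives a 1.2-fold lower number from compound 2 to compound 3 (0.07 log units; within the scatter), and cyclohexyl in place of butyl gives a 2.0-fold higher number from compound 1 to compound 3 (0.30 log units; within the scatter). The amide-type nitrogen thus takes a six-membered non-aromatic ring of carbon only in place of either open chain with neither step beyond the scatter, and the absence of a double bond in this group does not by itself reproduce the separation seen between compound 1 and compound 2: compound 3 lacks that double bond in this group, yet it stays within the scatter of compound 2 as well as of compound 1. No evidence on the reason for these numbers is available.

Still open, going by these compounds, is whether a longer chain such as octyl, a phenyl ring, or a cyclohexyl ring carrying an amine or a carboxylic acid on the same nitrogen would give a step beyond the scatter. The compounds shown vary only in the group on the amide-type nitrogen, so they give no reading of how the number responds to changes in the shared core.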